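From 4-cyanophenyl to 3,5-dibromo-4-hydroxyphenyl

The source may hold more compounds than are shown below. What is called first, only, known or untested is meant among the compounds shown, and "the series" means these compounds.

In a functional assay on MCF7 cells (Homo sapiens) for cytotoxicity, read by MTT assay, with a stated time of 72 h (a lower number here means a stronger inhibitor, a higher number a weaker inhibitor), the series offers a single number: compound 2 (`O=C(N/N=C/c1ccc(O)cc1)Nc1cc2c(Nc3ccc(F)c(Cl)c3)ncnc2cc1O[C@H]1CCOC1`) gives 910 nM. Compound 1 (`N#Cc1ccc(/C=N/NC(=O)Nc2cc3c(Nc4ccc(F)c(Cl)c4)ncnc3cc2O[C@H]2CCOC2)cc1`) is recorded as "not determined" (no result reported) with no result reported, and compound 3 (`COc1cc2ncnc(Nc3ccc(F)c(Cl)c3)c2cc1NC(=O)N/N=C/c1ccc(C#N)cc1`) is likewise recorded as "not determined" (no result reported) with no result reported, so compound 3 stands without a number of its own. Compound 4 (`COc1cc2ncnc(Nc3ccc(F)c(Cl)c3)c2cc1NC(=O)N/N=C/c1cc(Br)c(O)c(Br)c1`) carries 3,5-dibromo-4-hydroxyphenyl in place of 4-cyanophenyl on a carbon with a double bond to nitrogen. With no measured starting point, the size and direction of this step cannot be read from the data. Among the measured compounds shown here, the only anchor is compound 2 at 910 nM, and no shift beyond the scatter from that value is expected in this assay. Compound 4 is expected at 1000 nM, with an estimated range of 250 nM to 4500 nM.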

Compound 4, half-maximal inhibitory concentration: 30200 nM
For compound 4 the middle estimate is 30-fold (1.48 log units) below the measured one; the measured number lies above the stated range.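

In this assay no new step can be read from compound 3 to compound 4. The compounds shown leave open what 3,5-dibromo-4-hydroxyphenyl itself contributes to compound 4. Nothing shown offers an explanation for its value.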